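Cyclobutyl to cyclopentyl in a stable pair

A few compounds are considered here, and "the series" means these few. Any claim that something is new, unique, unknown or untested is made for them only; others in the source may bear on it.

Among the measured compounds shown here, in an ADME assay on microsomes from liver (Homo sapiens) for metabolic stability, with a stated time of 10 min (on this read-out lower numbers stand for a less stable compound and higher numbers for a more stable compound), compound 1 `O=C(O)[C@H]1CC[C@H](C(=O)N2CC[C@](c3ccc(C(OCc4c(F)cccc4Cl)(C(F)(F)F)C(F)(F)F)cc3)(S(=O)(=O)c3ccc(F)cc3)C2)CC1` reads 100% and compound 2 `O=C(O)[C@H]1CC[C@H](C(=O)N2CC[C@](c3ccc(C(OCC4CCC4)(C(F)(F)F)C(F)(F)F)cc3)(S(=O)(=O)c3ccc(F)cc3)C2)CC1` reads 85% which makes compound 2 the lower of the two numbers measured so far. Compound 3 `O=C(O)[C@H]1CC[C@H](C(=O)N2CC[C@](c3ccc(C(OCC4CCCC4)(C(F)(F)F)C(F)(F)F)cc3)(S(=O)(=O)c3ccc(F)cc3)C2)CC1` is still unmeasured and differs from compound 2 in a single group: cyclopentyl in place of cyclobutyl on a saturated chain carbon bound to an oxygen on a saturated carbon. For the measured compounds named here, only one measured step bears on this place, a number 15 percentage points lower from compound 1 to compound 2 (beyond the scatter) and this modest step came with cyclobutyl in place of 2-chloro-6-fluorophenyl. It offers only a loose guide, as it involved a different group, and no exchange of cyclobutyl for cyclopentyl has been measured. In this assay a small downward step that stays within the scatter is therefore expected, estimated as a number 4 percentage points lower from compound 2 to compound 3 (within the scatter) (no firm change). Compound 3 is estimated at 81% (expected range 66% to 95%).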

Compound 3, percent of the compound remaining: 73%
Compound 3: middle estimate off by 8 percentage points, on the high side; the range from low to high includes it.
By their numbers in this assay, from the lowest: compound 3; then compound 2; then compound 1.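

In this assay, exchanging cyclobutyl for cyclopentyl on a saturated chain carbon bound to an oxygen on a saturated carbon gives a number 12 percentage points lower from compound 2 to compound 3 (beyond the scatter), so this place responds even when one all-carbon ring replaces another that differs from it only in size. Exchanging 2-chloro-6-fluorophenyl for cyclopentyl at the same place gives a number 27 percentage points lower from compound 1 to compound 3 (beyond the scatter), which makes the three compounds a clear series: the number is highest with 2-chloro-6-fluorophenyl, lower with cyclobutyl and lowest with cyclopentyl. No measurement here explains why the number moves with these groups.

The compounds shown leave open whether the downward trend between the two saturated rings continues to cyclohexyl, or reverses with the smaller cyclopropyl, since two rings of neighbouring size only define a direction between themselves. They also leave open how an open chain such as isobutyl, or a ring that carries an oxygen, such as tetrahydropyranyl, or an amine, would read at this place on the same core.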